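This account rests on a few compounds, and the source may have more. Where it says the series, first, only, none or still open, it means among the compounds named here.

Measured compounds:

compound 1 `COc1ccc(-c2cc(/C=C/C(=O)c3ccc(N)cc3)[nH]n2)cc1` gives 2250 nM
compound 2 `COc1ccc(-c2cc(/C=C/C(=O)c3ccc(N)cc3)[nH]n2)cc1OC` gives 2740 nM
compound 3 `COc1cc(C(=O)/C=C/c2cc(-c3cc(OC)c(OC)c(OC)c3)n[nH]2)cc(OC)c1OC` gives 1540 nM

All three numbers come from a functional assay on SNB-75 cells (Homo sapiens) for inhibition, read by sulforhodamine B assay, with a stated time of 48 h; a higher number here means a weaker inhibitor of growth, a lower number a stronger inhibitor of growth. Going by the values given here, the step of a 1.2-fold lower number from compound 2 to compound 1 (0.09 log units; within the scatter) is the one counted change measured so far, (hydrogen in place of methoxy on an aromatic carbon). Compound 3 and compound 2 differ in more than one place, and the difference between the two cores is not broken down here; what the two values show is that they sit within the usual scatter of each other, as do all three numbers in this assay, so no ordering among compound 1, compound 2 and compound 3 is claimed.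

Compound 4 `COc1ccc(-c2cc(/C=C/C(=O)c3cc(OC)c(OC)c(OC)c3)[nH]n2)cc1OC` is not yet measured. It comes from compound 3 by hydrogen in place of methoxy on an aromatic carbon. Among the compounds with values here, this is the same kind of change as the one from compound 2 to compound 1, and not the same: around the place in compound 3 there is in addition a methoxy group meta to it, as given in its description, while around the place in compound 2 there is not. The step expected from compound 3 to compound 4 is small, a 1.0-fold lower number from compound 3 to compound 4 (0.01 log units; within the scatter), because a 1.2-fold lower number from compound 2 to compound 1 (0.09 log units; within the scatter) was within the scatter and nothing measured here points to a larger effect in the other direction. Within the data shown here, compound 4 is therefore estimated at 1500 nM in this assay, with a range from 700 nM to 3300 nM that reflects the scatter of one measurement of compound 3 and of the single comparable step.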

Compound 4, concentration for 50% growth inhibition: 1310 nM
The estimate for compound 4 lay 1.1-fold (0.06 log units) above the measured number, within the range that was stated.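

In this assay, hydrogen in place of methoxy on an aromatic carbon gives a 1.2-fold lower number from compound 3 to compound 4 (0.07 log units; within the scatter), so the same change can now be read on two cores, and the two steps agree: the same change on two cores in this assay, a 1.2-fold lower number (0.09 log units; within the scatter) from compound 2 to compound 1 and a 1.2-fold lower number (0.07 log units; within the scatter) from compound 3 to compound 4, 1.0-fold (0.02 log units) apart, within the scatter of two such steps. Within this series, the change therefore carries from the core of compound 2 to the core of compound 3 with no visible difference in its size, even though the place in compound 3 is also meta to a methoxy group. This does not show that the methoxy group at either place matters for growth inhibition, since each step lies within the scatter, and two pairs give no basis for a rule on other cores or at other places on the ring.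

The compounds shown leave open whether any replacement at these places would give a step beyond the scatter, as only hydrogen in place of methoxy can be read here. A hydroxyl group, a fluorine atom, a longer chain such as ethoxy or a carboxylic acid at the same places would test this, and the same replacement on both cores would show whether any such step carries from one core to the other.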